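The source may hold more compounds than are shown below. What is called first, only, known or untested is meant among the compounds shown, and "the series" means these compounds.

Measured compounds:
compound 1 `O=C(Nc1ccccc1Cl)N1CCN(c2nccc(Oc3cc(Cl)cc(Cl)c3)n2)CC1`, 11000 nM
compound 2 `O=C(Nc1ccc(C(F)(F)F)cc1)N1CCN(c2nccc(Oc3cc(Cl)cc(Cl)c3)n2)CC1`, 1540 nM
compound 3 `COc1cccc(Nc2ccnc(N3CCN(C(=O)Nc4ccc(C(F)(F)F)cc4)CC3)n2)c1`, 1240 nM

In a functional assay on MDA-MB-231 cells (Homo sapiens) for antiproliferative activity, read by MTT assay, with a stated time of 24 h (on this read-out lower numbers stand for stronger inhibition and higher numbers for weaker inhibition), compound 2 gives 1540 nM and compound 1 gives 11000 nM; the step of a 7.1-fold higher number from compound 2 to compound 1 (0.85 log units; beyond the scatter) goes with the change (2-chlorophenyl in place of 4-(trifluoromethyl)phenyl on an amide-type nitrogen). Compound 3 gives 1240 nM in this assay; its core differs from that of compound 2 by (3-methoxyphenyl)amino in place of 3,5-dichlorophenoxy on an aromatic carbon, with the step of a 1.2-fold lower number from compound 2 to compound 3 (0.09 log units; within the scatter). Compound 4 `COc1cccc(Nc2ccnc(N3CCN(C(=O)Nc4ccccc4Cl)CC3)n2)c1` is not yet measured in this assay; it differs from compound 3 by 2-chlorophenyl in place of 4-(trifluoromethyl)phenyl on an amide-type nitrogen, the same change at a place described in the same words. For compound 4 a step of about the same size is expected, a 6.5-fold higher number from compound 3 to compound 4 (0.81 log units; beyond the scatter), because the one measured case of this change is a 7.1-fold higher number from compound 2 to compound 1 (0.85 log units; beyond the scatter) on a core differing only by (3-methoxyphenyl)amino in place of 3,5-dichlorophenoxy on an aromatic carbon. Compound 4 is therefore estimated at 8000 nM in this assay, expected between 3000 nM and 20000 nM.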

Compound 4, half-maximal inhibitory concentration: 5260 nM
For compound 4 the middle estimate is 1.5-fold (0.18 log units) above the measured one, within the range that was stated.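

In this assay, 2-chlorophenyl in place of 4-(trifluoromethyl)phenyl on an amide-type nitrogen again goes with a weaker result, a 4.2-fold higher number from compound 3 to compound 4 (0.63 log units; beyond the scatter), and the two cores agree on this change: the same change on two cores in this assay, a 7.1-fold higher number (0.85 log units; beyond the scatter) from compound 2 to compound 1 and a 4.2-fold higher number (0.63 log units; beyond the scatter) from compound 3 to compound 4, 1.7-fold (0.23 log units) apart, within the scatter of two such steps. On the other hand, (3-methoxyphenyl)amino in place of 3,5-dichlorophenoxy on an aromatic carbon gives a 2.1-fold lower number from compound 1 to compound 4 (0.32 log units; beyond the scatter), beyond the scatter, whereas the earlier step on the other core lies within it, yet the two steps do not differ beyond the scatter: the same change on two cores in this assay, a 1.2-fold lower number (0.09 log units; within the scatter) from compound 2 to compound 3 and a 2.1-fold lower number (0.32 log units; beyond the scatter) from compound 1 to compound 4, 1.7-fold (0.23 log units) apart, within the scatter of two such steps. Both changes thus carry over between these cores, but this rests on a single square of four compounds and shows neither generality across other cores nor any reason for the steps.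

Still open, on these data alone, is how a plain phenyl or a cyclohexyl on the amide-type nitrogen would compare with these two groups. Also open, as far as these compounds go, is whether either step would hold with a morpholine or a simple amine on that aromatic carbon.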